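Oxan-4-yl for cyclohexyl: working notes on compound 4

This account rests on a few compounds, and the source may have more. Where it says the series, first, only, none or still open, it means among the compounds named here.

In a functional assay on the whole organism with Rattus norvegicus as the target (a lower number here means that less compound is needed, a higher number that more compound is needed for the effect), compound 1 (`CSc1nc(C)nc(SC)c1NC(=O)N(Cc1ccc(Oc2ccc(F)cc2)cc1)C1CCCCCC1`) gives 0.069 mg/kg. Compound 2 (`CSc1cc(C)nc(SC)c1NC(=O)N(Cc1cccc(Oc2ccc(Br)cc2)c1)C1CCCCCC1`) is reported only as a limit, < 0.1 mg/kg. Compound 3 (`CSc1cc(C)nc(SC)c1NC(=O)N(Cc1ccc(Oc2ccc(F)cc2)cc1)C1CCCCC1`) likewise has no number, only a limit, < 0.01 mg/kg. Compound 4 (`CSc1cc(C)nc(SC)c1NC(=O)N(Cc1ccc(Oc2ccc(F)cc2)cc1)C1CCOCC1`) keeps the rest of compound 3 and carries oxan-4-yl in place of cyclohexyl on an amide-type nitrogen. Among the compounds with values here, no measured pair isolates this change, so the expectation is tentative: in this assay, a move toward a higher dose, probably beyond the scatter. The expected change is an at least 5.0-fold higher number from compound 3 to compound 4 (0.69 log units; beyond the scatter), reckoned against a limit and not a number. For compound 4 the estimate is 0.05 mg/kg, with an expected range from 0.008 mg/kg to 0.5 mg/kg.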

Compound 4, dose for half-maximal effect: < 0.1 mg/kg
Compound 4: a limit, no number (the forecaster's own chance of this, stated with the estimate: 35%); the middle value lies beyond the limit too.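

Within the data shown here, compound 3 and compound 4 are each reported only as a limit, so no step between them can be read. Going by these compounds, whether oxan-4-yl in place of cyclohexyl shifts the dose, and in which direction, stays open.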